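Compound 3 to compound 4: phenyl to 4-chlorophenyl

A few compounds are considered here, and "the series" means these few. Any claim that something is new, unique, unknown or untested is made for them only; others in the source may bear on it.

In a functional assay on MCF7 cells (Homo sapiens) for antiproliferative activity (on this read-out higher numbers stand for weaker inhibition and lower numbers for stronger inhibition), compound 1 `O=C(Nc1ccc(O)c2c(=O)cc(-c3ccccc3Cl)oc12)c1ccccc1` gives 7100 nM, compound 2 `O=C(Nc1ccc(O)c2c(=O)cc(-c3ccccc3Cl)oc12)c1ccc(Cl)cc1` gives 4600 nM and compound 3 `O=C(Nc1c(O)cc(O)c2c(=O)cc(-c3ccccc3Cl)oc12)c1ccccc1` gives 8500 nM. All three numbers lie within the scatter of one another, so compound 3 cannot be ranked against the other two.

Compound 4 `O=C(Nc1c(O)cc(O)c2c(=O)cc(-c3ccccc3Cl)oc12)c1ccc(Cl)cc1` differs from compound 3 by chloro in place of hydrogen on an aromatic carbon, para to a large group, which reads as phenyl to 4-chlorophenyl.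

The same change has been measured once, as a 1.5-fold lower number from compound 1 to compound 2 (0.19 log units; within the scatter), and that step stays within the scatter. The hydroxy step, a 1.2-fold higher number from compound 1 to compound 3 (0.08 log units; within the scatter), is also within the scatter and is already part of the starting point here. A single small step is weak evidence, so no change beyond the scatter is expected in this assay, only a possible slight move towards a lower number.

The expected step is a 1.4-fold lower number from compound 3 to compound 4 (0.15 log units; within the scatter). For compound 4 the estimated value is 6000 nM, with an expected range of 3200 nM to 11000 nM.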

Compound 4, half-maximal inhibitory concentration: 13000 nM
The estimate for compound 4 lay 2.2-fold (0.34 log units) below the measured number; measured number outside the range, above it.
By their numbers in this assay, from the lowest: compounds 2, 1, 3 and 4 (each within the scatter of the next, the first and the last beyond it).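

In this assay chloro in place of hydrogen on an aromatic carbon, para to a large group, now gives a step in the opposite direction on the dihydroxy core (in words of the step: a 1.5-fold higher number from compound 3 to compound 4 (0.18 log units; within the scatter)), so phenyl to 4-chlorophenyl shows no consistent direction across the two cores: the same change on two cores in this assay, a 1.5-fold lower number (0.19 log units; within the scatter) from compound 1 to compound 2 and a 1.5-fold higher number (0.18 log units; within the scatter) from compound 3 to compound 4, 2.4-fold (0.37 log units) apart, within the scatter of two such steps. Within the data shown here, the hydroxy change now gives the first step beyond the scatter, though only a modest one (a 2.8-fold higher number from compound 2 to compound 4 (0.45 log units; beyond the scatter)), and the two hydroxy steps do not separate: the same change on two cores in this assay, a 1.2-fold higher number (0.08 log units; within the scatter) from compound 1 to compound 3 and a 2.8-fold higher number (0.45 log units; beyond the scatter) from compound 2 to compound 4, 2.4-fold (0.37 log units) apart, within the scatter of two such steps. These four compounds therefore support no claim that the effect of one change depends on the other.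

Open, as far as these compounds go, is whether another group at this place, such as methoxy or an amine, would shift the number beyond the scatter. Also open, from the compounds shown here alone, is whether a carboxylic acid there would do so on either core.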